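This account rests on a few compounds, and the source may have more. Where it says the series, first, only, none or still open, it means among the compounds named here.

Of the compounds shown here, two have been measured so far in an ADME assay on the whole organism (Rattus norvegicus, strain Sprague-Dawley) for pharmacokinetics, using cassette dosing, at a dose of 1 mg/kg by the oral route; on this read-out higher numbers stand for higher oral bioavailability and lower numbers for lower oral bioavailability. Compound 1 (`O[C@]1(Cc2cc(-c3cn[nH]c3)on2)CC[C@@H](Cc2ccc(C(F)(F)F)cc2)CC1`) gives 67.5%, whereas compound 2 (`O=C(c1cc(-c2cn[nH]c2)on1)N1CCC(Cc2ccccc2)CC1`) gives 0.2%, the lower of the two numbers and well beyond the scatter. Compound 3 (`O=C(c1cc(-c2cn[nH]c2)on1)N1CCC(Cc2ccc(Cl)cc2)CC1`) is compound 2 with a single change: chloro in place of hydrogen on an aromatic carbon. The new chloro sits para to a large group. Within the data shown here, no measured pair differs in only one place, so the data do not show directly what this change does. Compounds 1 and 2 differ in several places, so their gap cannot be credited to this one position. A small rise, within the scatter, is expected as the step of a number 1.8 percentage points higher from compound 2 to compound 3 (within the scatter). Compound 3 is therefore estimated at 2%, with an expected range from 0% to 12%.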

Compound 3, oral bioavailability: 0.6%
For compound 3 the middle estimate is 1.4 percentage points above the measured one, within the range that was stated.
By their numbers in this assay, from the lowest: compounds 2 and 3 (each within the scatter of the next); then compound 1.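

Among these compounds, compounds 2 and 3 form the first pair here that differs in one place only, so this change can now be read directly: going from phenyl to 4-chlorophenyl gives, in this assay, a number 0.4 percentage points higher from compound 2 to compound 3 (within the scatter) on oral bioavailability. Chloro on this aromatic carbon, para to a large group, therefore does not separate the two compounds on this read-out, and the hydrogen and the chloro cannot be told apart here. Nothing measured here explains this result.

From the compounds shown here alone, whether another group at this same position, such as fluoro, methoxy or an amine, would give a different number remains open. Also open is which of the several places where compound 1 differs from compound 2 accounts for the gap between their numbers.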